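The compounds below may be only part of what the source reports. "The series", "measured", "known", "first", "only" and "open" are said of these compounds alone.

Working notes on the series. All compounds share one core and differ in the aryl group on a saturated ring carbon of the amine ring attached to the amide. Compound 1 `COc1ccc(-n2nc(Sc3ccc(Cl)cc3)cc(CC[C@@H](C)NC(=O)[C@H]3CCNC[C@@H]3c3ccc(Cl)cc3Cl)c2=O)cc1` gives 2400 nM in a functional assay with Melanocortin receptor 4 (Homo sapiens) as the target, read by cAMP accumulation; on this read-out higher numbers stand for an effect only at larger amounts of compound and lower numbers for an effect already at smaller amounts. Within the data shown here, compound 2 `COc1ccc(-n2nc(Sc3ccc(Cl)cc3)cc(CC[C@@H](C)NC(=O)[C@H]3CCNC[C@@H]3c3ccc(C#N)cc3)c2=O)cc1` gives 120 nM in this assay, the one measured step here, a 20-fold lower number from compound 1 to compound 2 (1.30 log units; beyond the scatter), being the only direct comparison of two aryl groups on the same ring carbon. Compound 3 `COc1ccc(-n2nc(Sc3ccc(Cl)cc3)cc(CC[C@@H](C)NC(=O)[C@H]3CNC[C@@H]3c3ccccc3F)c2=O)cc1` carries a five-membered saturated ring where compounds 1 and 2 carry a six-membered one. In this assay compound 3 gives 710 nM; among the three numbers it stands second highest, with compound 1 at a higher number and compound 2 at a lower one, both gaps beyond the scatter.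

Compound 4 `COc1ccc(-n2nc(Sc3ccc(Cl)cc3)cc(CC[C@@H](C)NC(=O)[C@H]3CNC[C@@H]3c3ccc(Cl)cc3)c2=O)cc1` is not yet measured. The change from compound 3 is 4-chlorophenyl in place of 2-fluorophenyl on a saturated ring carbon. Among the measured compounds shown here, no step on the five-membered ring is available, so the expectation rests on the step from compound 1 to compound 2, where an aryl group bearing a halogen at the 2-position gave way to a 4-substituted one and the number fell strongly; the present change is of the same kind but smaller in substituent content, so a lowering beyond the scatter, though well short of that earlier step, is expected. Compound 4 is therefore expected in this assay at about 300 nM, within 100 nM to 900 nM. The expected step is a 2.4-fold lower number from compound 3 to compound 4 (0.37 log units; beyond the scatter).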

Compound 4, half-maximal effective concentration: 230 nM
Compound 4: the middle estimate sits 1.3-fold (0.12 log units) above what was measured; measured number inside the range.
By their numbers in this assay, from the lowest: compounds 2 and 4 (each within the scatter of the next); then compound 3; then compound 1.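

Among these compounds, on the five-membered ring, the aryl group on this saturated ring carbon also moves the number in this assay, with a 3.1-fold lower number from compound 3 to compound 4 (0.49 log units; beyond the scatter) giving the first measured aryl comparison on that ring. Together with a 20-fold lower number from compound 1 to compound 2 (1.30 log units; beyond the scatter) on the six-membered ring, this gives two steps in the same direction, both from a phenyl bearing a halogen at the 2-position to a 4-substituted phenyl, and neither of the compounds shown goes against this, although the pairs share no aryl groups and the pattern rests on these four compounds alone. Nothing at hand bears on why the number moves with these aryl changes.

The step from 2-fluorophenyl to 4-chlorophenyl changes both the halogen and where it sits on the phenyl, so the compounds shown cannot assign the step to either change, which 2-chlorophenyl or 4-fluorophenyl on the same ring carbon would separate. Also open, on these data alone, are unsubstituted phenyl and 4-cyanophenyl on the five-membered ring, along with any group other than an aryl at this ring carbon, such as a cyclohexyl or a longer alkyl chain.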